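This account rests on a few compounds, and the source may have more. Where it says the series, first, only, none or still open, it means among the compounds named here.

Compound 1 `C=C1[C@@H](OC(C)=O)C[C@@H]2[C@](C)(CO[Si](C)(C)C(C)(C)C)[C@H](OC(C)=O)CC[C@@]2(C)[C@@H]1C[C@@H](Nc1ccc(C(=O)O)cc1)C1=CCOC1=O` and compound 2 `C=C1[C@@H](OC(C)=O)C[C@@H]2[C@](C)(COC=O)[C@H](OC(C)=O)CC[C@@]2(C)[C@@H]1C[C@@H](Nc1ccc(C(=O)O)cc1)C1=CCOC1=O` share one core and differ only at an oxygen on a saturated carbon. In a functional assay on HT-29 cells (Homo sapiens) for cytotoxicity, read by sulforhodamine B assay (a higher number here means a weaker inhibitor, a lower number a stronger inhibitor), compound 1 gives 4630 nM, the lowest of the two numbers, and compound 2 gives 37200 nM; the step of an 8.0-fold higher number from compound 1 to compound 2 (0.90 log units; beyond the scatter) lies beyond the scatter. Compound 3 `C=C1[C@@H](OC(C)=O)C[C@@H]2[C@](C)(CO[Si](C)(C)C(C)(C)C)[C@H](OC(C)=O)CC[C@@]2(C)[C@@H]1C[C@@H](Nc1cccc(OC)c1)C1=CCOC1=O` keeps the silyl ether of compound 1 and changes the aryl on the amine nitrogen: 3-methoxyphenyl in place of 4-carboxyphenyl on an amine nitrogen. Within the data shown here, no measured step touches this position, so nothing here tells the direction; the only measured step sits elsewhere. Compound 3 is therefore expected near compound 1, with a wide range, at 3000 nM between 700 nM and 13000 nM, which means an expected step of a 1.5-fold lower number from compound 1 to compound 3 (0.19 log units; within the scatter).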

Compound 3, half-maximal inhibitory concentration: > 50000 nM
Compound 3 was reported as a limit (the forecaster's own chance of this, stated with the estimate: 5%); middle value at least 16-fold (1.22 log units) away from the limit.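

With the silyl ether kept, 3-methoxyphenyl in place of 4-carboxyphenyl on an amine nitrogen gives an at least 10-fold higher number from compound 1 to compound 3 (1.03 log units; beyond the scatter), so the aryl at this position, untouched by the earlier step, strongly affects the read-out in this assay. The value for compound 3 is a limit of the assay and not a number: the limit of > 50000 nM in this assay, at which 1 of the 3 values shown sits.

The compounds shown do not separate the loss of the 4-carboxyphenyl group from the entry of the 3-methoxyphenyl group. From the compounds shown here alone, how an unsubstituted phenyl, or an amide or ester in place of the carboxylic acid, would read remains open.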